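Cyano in Place of Hydroxy: Compound 3 to Compound 4

The source may report more compounds than this note shows. Statements on the series, on what has been measured and on what is new or still open speak of the compounds shown alone.

Compound 3 `CC1(C)[C@H]2CC[C@]1(C)N(Cc1cn(-c3ccccc3O)nn1)C(=O)C2` gives 540 nM in a functional assay on LoVo cells (Homo sapiens) for inhibition, read by MTT assay, with a stated time of 24 h (on this read-out lower numbers stand for stronger inhibition and higher numbers for weaker inhibition), the highest number among the three measured compounds. Compound 1 `CC1(C)[C@H]2CC[C@]1(C)N(Cc1cn(-c3ccc(Cl)cc3)nn1)C(=O)C2` gives 160 nM and compound 2 `Cc1ccccc1-n1cc(CN2C(=O)C[C@@H]3CC[C@@]2(C)C3(C)C)nn1` gives 80 nM. The measured steps toward compound 3 were a 3.4-fold higher number from compound 1 to compound 3 (0.53 log units; beyond the scatter) and a 6.8-fold higher number from compound 2 to compound 3 (0.83 log units; beyond the scatter), while a 2.0-fold lower number from compound 1 to compound 2 (0.30 log units; within the scatter). Compound 4 `CC1(C)[C@H]2CC[C@]1(C)N(Cc1cn(-c3ccccc3C#N)nn1)C(=O)C2` differs from compound 3 by cyano in place of hydroxy on an aromatic carbon. The step on the same aromatic carbon bears most directly on this change, because a 6.8-fold higher number from compound 2 to compound 3 (0.83 log units; beyond the scatter) shows that hydroxy gave the weakest result there. Cyano is not methyl, so only part of that reversal is expected. Compound 4 is therefore expected to give 200 nM, in the range 60 nM to 650 nM. This estimate means an expected step of a 2.7-fold lower number from compound 3 to compound 4 (0.43 log units; beyond the scatter).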

Compound 4, half-maximal inhibitory concentration: 140 nM
Compound 4: the middle estimate sits 1.4-fold (0.15 log units) above what was measured; the range from low to high includes it.
By their numbers in this assay, from the lowest: compounds 2, 4 and 1 (each within the scatter of the next); then compound 3.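

In this assay, cyano in place of hydroxy on this aromatic carbon gives a 3.9-fold lower number from compound 3 to compound 4 (0.59 log units; beyond the scatter), so the weak result of compound 3 does not extend to every group other than methyl here. Cyano and methyl at this place cannot be told apart, with a 1.8-fold higher number from compound 2 to compound 4 (0.24 log units; within the scatter) lying within the scatter, and the same holds for the 2-cyanophenyl and 4-chlorophenyl groups, with a 1.1-fold lower number from compound 1 to compound 4 (0.06 log units; within the scatter). No measurement at hand speaks to the reason for these results. From the compounds shown here alone, whether an amine or a carboxylic acid on this carbon would track hydroxy or cyano stays open. So does the effect of cyano elsewhere on the six-membered aromatic ring.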